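A few compounds are considered here, and "the series" means these few. Any claim that something is new, unique, unknown or untested is made for them only; others in the source may bear on it.

Compound 1, `Cc1cc(NCc2ccccn2)n2ncc(-c3ccc(F)cc3F)c2n1`; compound 2, `Cc1cc(NCc2ccccn2)n2ncc(-c3ccncc3)c2n1`.

In a physicochemical assay for solubility, read by HPLC, using the shake flask method, measured as kinetic solubility, with a stated time of 2 h, at pH 7.4 (on this read-out higher numbers stand for higher solubility and lower numbers for lower solubility), compound 1 gives only a limit of the assay, < 5000 nM. In this assay, for the measured compounds named here, compound 2 gives 161000 nM, the only number among the two values shown. The step of an at least 32-fold higher number from compound 1 to compound 2 (1.50 log units; beyond the scatter) is read against (the limit of < 5000 nM in this assay, at which 1 of the 2 values shown sits), so its size is known only as a lower bound. Compound 3, `Cc1cc(NCc2ccccn2)n2ncc(-c3ccn(C)n3)c2n1`, differs from compound 2 in one place: 1-methyl-1H-pyrazol-3-yl in place of pyridin-4-yl on an aromatic carbon. Going by the values given here, no measured step bears directly on this change; the single measured step exchanged a 2,4-difluorophenyl for a pyridin-4-yl, not a pyridin-4-yl for a 1-methyl-1H-pyrazol-3-yl, and gives no guide to its size or direction. Compound 3 is therefore expected to show a 1.3-fold lower number from compound 2 to compound 3 (0.13 log units; within the scatter), a step within the scatter. Compound 3 is estimated in this assay at 120000 nM, with a range from 30000 nM to 300000 nM.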

Compound 3, solubility: 188000 nM
The estimate for compound 3 lay 1.6-fold (0.19 log units) below the measured number; the measured number falls inside the stated range.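

In this assay, placing 1-methyl-1H-pyrazol-3-yl instead of pyridin-4-yl on this aromatic carbon gives a 1.2-fold higher number from compound 2 to compound 3 (0.07 log units; within the scatter) and so does not separate the two groups, although one is a six-membered aromatic ring with 1 hetero atom and the other a five-membered aromatic ring with 2 hetero atoms. Pyridin-4-yl is therefore no longer the only group at this position with a measured number in this range. Against 2,4-difluorophenyl the new group shows an at least 37-fold higher number from compound 1 to compound 3 (1.57 log units; beyond the scatter) and that size is known only as a lower bound: the limit of < 5000 nM in this assay, at which 1 of the 3 values shown sits.

The compounds shown leave open whether a group without an aromatic ring, such as morpholine, or a carboxylic acid at this position would give a number in the same range. They also leave open whether the two groups would still match with the rest of the shared core changed.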